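Replacing an Amide Substituent in an Alkyne-Linked Amide Series

The source may report more compounds than this note shows. Statements on the series, on what has been measured and on what is new or still open speak of the compounds shown alone.

Compound 1 `CC1CCC(NC(=O)c2ccc(C#Cc3ccccc3)nc2)CC1`: 1200 nM
Compound 2 `O=C(NCc1ccsc1)c1ccc(C#Cc2ccccc2)cc1`: 1200 nM
Compound 3 `CC1CCN(C(=O)c2ccc(C#Cc3ccccc3)cc2)CC1`: 720 nM

All three compounds were measured in a functional assay on BHK cells for positive allosteric modulation of metabotropic glutamate receptor 5 (Homo sapiens), read by FLIPR and calcium flux; on this read-out higher numbers stand for an effect only at larger amounts of compound and lower numbers for an effect already at smaller amounts. Compound 1 stands level with compound 2 at the digits shown, and together they give the highest numbers of the three. Its nearest neighbour is compound 2, with no change at the digits shown, and its furthest is compound 3, whose value of 720 nM still lies within the scatter of that of compound 1.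

Compound 4 `CN1CCN(C(=O)c2ccc(C#Cc3ccccc3)nc2)CC1` has not yet been measured. It differs from compound 1 in a single place: 4-methylpiperazin-1-yl in place of (4-methylcyclohexyl)amino on a carbonyl carbon. Among the compounds with values here, the one measured step that bears on this is a 1.7-fold lower number from compound 2 to compound 3 (0.22 log units; within the scatter), in which a group carrying the amide hydrogen was exchanged for a ring nitrogen bonded directly to the carbonyl, the same kind of exchange as from compound 1 to compound 4. That step was within the scatter, so no step beyond the scatter is expected here, as in a 1.2-fold lower number from compound 1 to compound 4 (0.08 log units; within the scatter). For compound 4 the expected value in this assay is 1000 nM, with a range from 400 nM to 3000 nM.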

Compound 4, half-maximal effective concentration: 1600 nM
The estimate for compound 4 lay 1.6-fold (0.20 log units) below the measured number; the measured number falls inside the stated range.
By their numbers in this assay, from the lowest: compounds 3, 1, 2 and 4 (each within the scatter of the next, the first and the last beyond it).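

In this assay, 4-methylpiperazin-1-yl in place of (4-methylcyclohexyl)amino on the carbonyl carbon gives a 1.3-fold higher number from compound 1 to compound 4 (0.12 log units; within the scatter), so this position accepts a ring with hetero atoms, and the loss of the amide hydrogen, without a step beyond the scatter. Until now only a 1.7-fold lower number from compound 2 to compound 3 (0.22 log units; within the scatter) spoke for this kind of exchange, on a slightly different core; there are now two such steps, both within the scatter, and no compound shown goes against them. Nothing measured here accounts for why the number stays at this level.

The change from compound 1 to compound 4 alters the ring and the amide hydrogen at once, so the two cannot be told apart here, and 4-methylpiperidin-1-yl on the core of compound 1 would be needed to separate them. Going by these compounds, how far this tolerance reaches also stays open, for example with morpholin-4-yl, with an open-chain dimethylamino group, or with a carboxylic acid carried on the ring.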